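Cytotoxicity notes on the series ahead of compound 4

This account rests on a few compounds, and the source may have more. Where it says the series, first, only, none or still open, it means among the compounds named here.

Measured so far in a functional assay on PC-12 cells (Rattus norvegicus) for cytotoxicity, read by MTT assay, with stated times of 2 h and 24 h, tested at 5 uM; on this read-out lower numbers stand for a weaker effect and higher numbers for a stronger effect at the one concentration tested:
compound 1, `CC(C)(C)c1ccc(-n2nc(-c3ccc(C(F)(F)F)cc3O)nc2-c2ccccc2O)cc1`, gives 77.8%
compound 2, `Oc1cc(C(F)(F)F)ccc1-c1nc(-c2ccccc2O)n(-c2ccccc2F)n1`, gives 86.6%
compound 3, `Oc1cc(C(F)(F)F)ccc1-c1nc(-c2ccccc2O)n(-c2ccc(F)cc2F)n1`, gives 83.5%

All three numbers sit close together. Compound 3 stands second highest of the three; its nearest neighbour is compound 2, with a number 3.1 percentage points lower from compound 2 to compound 3 (within the scatter), and its furthest is compound 1, with a number 5.7 percentage points higher from compound 1 to compound 3 (within the scatter). The remaining step, a number 8.8 percentage points higher from compound 1 to compound 2 (within the scatter), is likewise within the scatter. Among the compounds with values here, nothing among the measured compounds therefore moves this read-out beyond noise.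

Compound 4, `Oc1cc(C(F)(F)F)ccc1-c1nc(-c2ccccc2O)n(-c2cc(F)cc(F)c2)n1`, is the next compound. Its change from compound 3 is 3,5-difluorophenyl in place of 2,4-difluorophenyl on an aromatic nitrogen. Within the data shown here, the steps that bear on it are those altering the group on the aromatic nitrogen: a number 8.8 percentage points higher from compound 1 to compound 2 (within the scatter) and a number 5.7 percentage points higher from compound 1 to compound 3 (within the scatter) exchange the whole group, and a number 3.1 percentage points lower from compound 2 to compound 3 (within the scatter) adds a single fluoro to it. Every one of these lies within the scatter, so no change beyond the scatter is expected for compound 4; the expected step is a number 0.5 percentage points lower from compound 3 to compound 4 (within the scatter). Compound 4 is accordingly estimated at 83%, with a range from 72% to 93%.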

Compound 4, a percentage reported as activity, at one concentration (the size of the read-out at that concentration, not a potency): 100%
Beside the measured number, compound 4's estimate is 17 percentage points below it; the measured number lies above the stated range.
By their numbers in this assay, from the lowest: compounds 1, 3 and 2 (each within the scatter of the next); then compound 4.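

In this assay the group on the aromatic nitrogen now moves the read-out beyond the scatter: a number 16.5 percentage points higher from compound 3 to compound 4 (beyond the scatter) arises with both groups holding the same atoms, so the placement of the two fluoro atoms on the phenyl ring matters here, which neither exchanging the whole group nor adding a single fluoro had shown among the earlier compounds. The other two comparisons point the same way, with a number 13.4 percentage points higher from compound 2 to compound 4 (beyond the scatter) and a number 22.2 percentage points higher from compound 1 to compound 4 (beyond the scatter) as well, so the 3,5-difluorophenyl group gives the strongest effect of the four at the one concentration tested. No measurement at hand accounts for the gap between the 2,4-difluorophenyl and 3,5-difluorophenyl groups.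

From the compounds shown here alone, whether both fluoro atoms are needed remains open, as does whether the effect carries over to groups such as 3-fluorophenyl, 3,5-dichlorophenyl or 3,5-dimethoxyphenyl on the same nitrogen. With a single concentration for each compound, the compounds shown also leave open how this difference would look across a range of concentrations.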